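Acetyl to Propanoyl Across Two Related Cores

The compounds below may be only part of what the source reports. "The series", "measured", "known", "first", "only" and "open" are said of these compounds alone.

Compound 1 `CC(=O)NC1CCN(S(=O)(=O)c2ccc(F)cc2)CC1` and compound 2 `CCC(=O)NC1CCN(S(=O)(=O)c2ccc(F)cc2)CC1` differ by methyl in place of hydrogen on a saturated chain carbon bound to a carbonyl carbon. In a functional assay on the whole organism with Mus musculus as the target, with a stated time of 30 min (a lower number here means that less compound is needed, a higher number that more compound is needed for the effect), compound 1 gives 0.01 mg/kg and compound 2 gives 0.1 mg/kg, so that the change brought a 10-fold higher number from compound 1 to compound 2 (1.00 log units; beyond the scatter). Compound 3 `CC(=O)N1CCN(S(=O)(=O)c2ccc(F)cc2)CC1=O` is built on a different core; the difference between the two cores is not broken down here. In this assay compound 3 gives 0.3 mg/kg, the highest of the three measured numbers. Compound 4 `CCC(=O)N1CCN(S(=O)(=O)c2ccc(F)cc2)CC1=O` has not yet been measured. It differs from compound 3 by methyl in place of hydrogen on a saturated chain carbon bound to a carbonyl carbon, the same change at the same place as that between compound 1 and compound 2, so the change occurs twice among these compounds. On that basis the author expects compound 4 to need more compound than compound 3, with an estimated step of a 10-fold higher number from compound 3 to compound 4 (1.00 log units; beyond the scatter) in this assay, resting only on the earlier step of a 10-fold higher number from compound 1 to compound 2 (1.00 log units; beyond the scatter) seen on the other core. Compound 4 is therefore estimated at 3 mg/kg, with an expected range from 1 mg/kg to 10 mg/kg.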

Compound 4, minimum effective dose: 0.3 mg/kg
Compound 4: the middle estimate sits 10-fold (1.00 log units) above what was measured; the whole stated range lies above it.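

In this assay the same methyl in place of hydrogen gave no change at the digits printed from compound 3 to compound 4 (within the scatter), so the earlier result did not carry over to the core of compound 3. Set side by side, the two steps show that the effect of this change depended on the core in these two pairs: the same change on two cores in this assay, a 10-fold higher number (1.00 log units; beyond the scatter) from compound 1 to compound 2 and no change at the digits printed (within the scatter) from compound 3 to compound 4, 10-fold (1.00 log units) apart, beyond the scatter of two such steps. Going by these compounds alone, this is enough to show that the step seen on one core cannot be assumed to hold on the other, but with only two pairs it does not show which part of the difference between the cores is responsible or how the change would behave on any further core.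

The compounds shown carry only acetyl and propanoyl at this place, so it remains open how a longer chain such as butanoyl or a branched group such as isobutyryl would read on either core. All four compounds also share the fluorine, leaving open whether the same contrast would hold with chlorine or a methoxy group in its place.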